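Swapping cyclohexyl for butyl in a growth inhibitor

A few compounds are considered here, and "the series" means these few. Any claim that something is new, unique, unknown or untested is made for them only; others in the source may bear on it.

Going by the values given here, in a functional assay on MCF7 cells (Homo sapiens) for inhibition, read by fluorescence, with a stated time of 72 h (a lower number here means a stronger inhibitor of growth, a higher number a weaker inhibitor of growth), compound 1 `N[C@H]1CC[C@H](Nc2nc(Nc3ccc(Cl)cc3)c3ncn(C4CCCCC4)c3n2)CC1` gives 2300 nM, the lower of the two numbers measured so far. Compound 2 `N[C@H]1CC[C@H](Nc2nc(Nc3ccc(O)cc3)c3ncn(C4CCCCC4)c3n2)CC1` gives 9600 nM in this assay. These two differ at a single place, with hydroxy in place of chloro on an aromatic carbon, and that change produced a 4.2-fold higher number from compound 1 to compound 2 (0.62 log units; beyond the scatter).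

Compound 3 `CCCCn1cnc2c(Nc3ccc(Cl)cc3)nc(N[C@H]3CC[C@H](N)CC3)nc21` leaves that chloro group alone and changes a different part of compound 1, an aromatic nitrogen of the shared core, where butyl takes the place of cyclohexyl: butyl in place of cyclohexyl on an aromatic nitrogen. Among the compounds with values here, no measured step involves this nitrogen, so the data offer no direct evidence on the effect of this swap. Within the data shown here, the one step from compound 1 to compound 2 serves only as a rough guide to how far a single change can move the number in this small set. A step no larger than that one is therefore expected in this assay, leaning weakly towards a higher number. The step expected is a 1.7-fold higher number from compound 1 to compound 3 (0.24 log units; within the scatter). For compound 3, the estimated value is 4000 nM, with an expected range of 1500 nM to 11000 nM.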

Compound 3, concentration for 50% growth inhibition: 2100 nM
For compound 3 the middle estimate is 1.9-fold (0.28 log units) above the measured one, within the range that was stated.
By their numbers in this assay, from the lowest: compounds 3 and 1 (each within the scatter of the next); then compound 2.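

At this aromatic nitrogen of the shared core, butyl in place of cyclohexyl gives a 1.1-fold lower number from compound 1 to compound 3 (0.04 log units; within the scatter) in this assay, so the two numbers cannot be told apart. Until now, every compound carried cyclohexyl here, so nothing showed whether the ring itself mattered; with the chloro group in place, this pair shows that a chain with no ring can stand at this nitrogen without a shift beyond the scatter, whereas the change on the aromatic carbon gave a 4.2-fold higher number from compound 1 to compound 2 (0.62 log units; beyond the scatter). No measurement available here accounts for how closely the cyclohexyl and butyl compounds agree.

This single pair cannot show how much freedom the position allows: a much shorter group such as methyl, a longer chain such as octyl, a flat ring such as phenyl, or a chain ending in an amine or a carboxylic acid could each give a very different number. It also leaves open whether butyl would match cyclohexyl in the same way with hydroxy on the aromatic ring, as in compound 2, where the surroundings of the swap differ.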